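The source may report more compounds than this note shows. Statements on the series, on what has been measured and on what is new or still open speak of the compounds shown alone.

Compound 1 `Cc1ccccc1Nc1ncnn1-c1cccc(Cl)c1Cl` gives 240 nM in a functional assay for antagonist activity at P2X purinoceptor 7 (Rattus norvegicus), read by FLIPR and calcium flux; a lower number here means a stronger inhibitor, a higher number a weaker inhibitor. Compound 2 `CCc1ccccc1Nc1ncnn1-c1cccc(Cl)c1Cl` gives 288 nM in this assay. The change methyl in place of hydrogen on a saturated chain carbon bound to an aromatic carbon gave a 1.2-fold higher number from compound 1 to compound 2 (0.08 log units; within the scatter). Compound 3 `COc1ccccc1CNc1ncnn1-c1cccc(Cl)c1Cl` gives 708 nM in this assay, the highest of the three numbers; how its core differs from the core of compound 1 is not broken down here. Compound 4 `CCOc1ccccc1CNc1ncnn1-c1cccc(Cl)c1Cl` is not yet measured. It differs from compound 3 by methyl in place of hydrogen on a saturated chain carbon bound to an oxygen on an aromatic ring. Within the data shown here, this is the same kind of change as the one between compound 1 and compound 2, though the place is not identical: in the earlier pair the saturated chain carbon is bound to an aromatic carbon, here it is bound to an oxygen on an aromatic ring. Beside a 1.2-fold higher number from compound 1 to compound 2 (0.08 log units; within the scatter), the step of a 1.1-fold higher number from compound 3 to compound 4 (0.03 log units; within the scatter) is expected, resting on the earlier step having stayed within the scatter in this assay. Compound 4 is accordingly estimated at 750 nM, expected between 350 nM and 1600 nM.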

Compound 4, half-maximal inhibitory concentration: 490 nM
Compound 4: middle estimate off by 1.5-fold (0.18 log units), on the high side, within the range that was stated.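

Methyl in place of hydrogen on a saturated chain carbon bound to an oxygen on an aromatic ring gave a 1.4-fold lower number from compound 3 to compound 4 (0.16 log units; within the scatter) in this assay. Set beside the earlier step, the change shows no readable difference between the two cores: the same change on two cores in this assay, a 1.2-fold higher number (0.08 log units; within the scatter) from compound 1 to compound 2 and a 1.4-fold lower number (0.16 log units; within the scatter) from compound 3 to compound 4, 1.7-fold (0.24 log units) apart, within the scatter of two such steps. Among these compounds, this shows only that the change stayed within the scatter in both pairs; with two pairs, differing in place and with neither step large enough to give a direction, it sets no rule for other cores or places.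

The compounds shown leave open whether a chain longer than ethoxy would move the number beyond the scatter. On these data alone, an amine or a carboxylic acid at the end of that chain also remains open.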